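This account rests on a few compounds, and the source may have more. Where it says the series, first, only, none or still open, it means among the compounds named here.

Measured compounds and their values:
- compound 1, `CC(C)c1ccccc1OS(=O)(=O)c1ccc(NC(=O)C(C)(C)C)cc1`: 6500 nM in a functional assay on MCF7 cells (Homo sapiens) for antiproliferative activity, read by sulforhodamine B assay, with a stated time of 48 h; a lower number here means a stronger inhibitor, a higher number a weaker inhibitor
- compound 2, `CC(C)c1ccccc1OS(=O)(=O)c1ccc(NC(=O)CCCl)cc1`: 9000 nM in this assay

Both compounds share the same core and differ only in the group on the carbonyl carbon of the amide. For the measured compounds named here, the one measured step between them, a 1.4-fold higher number from compound 1 to compound 2 (0.14 log units; within the scatter), is within the scatter, so compound 2 stands alongside compound 1 rather than apart from it; nothing in these two numbers separates them.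

Compound 3, `CCCNC(=O)Nc1ccc(S(=O)(=O)Oc2ccccc2C(C)C)cc1`, is not yet measured. It differs from compound 2 in one place: propylamino in place of 2-chloroethyl on a carbonyl carbon. Going by the values given here, the only measured step that bears on this change is the one from compound 1 to compound 2, which also swapped the group on that carbonyl carbon and stayed within the scatter. Among the compounds with values here, no measured step shows the effect of bringing in a hydrogen-bond donor at that place, so the expectation rests on the single neighbouring step alone. On that basis no step beyond the scatter is expected in this assay, and a change of about a 1.1-fold lower number from compound 2 to compound 3 (0.05 log units; within the scatter) is estimated. Compound 3 is therefore expected to give roughly 8000 nM, with a range from 3000 nM to 22000 nM.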

Compound 3, half-maximal inhibitory concentration: 2700 nM
Compound 3: middle estimate off by 3.0-fold (0.47 log units), on the high side; the measured number lies below the stated range.
By their numbers in this assay, from the lowest: compound 3; then compounds 1 and 2 (each within the scatter of the next).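

In this assay the group on this carbonyl carbon turns out to matter: propylamino in place of 2-chloroethyl gives a 3.3-fold lower number from compound 2 to compound 3 (0.52 log units; beyond the scatter) and propylamino in place of tert-butyl gives a 2.4-fold lower number from compound 1 to compound 3 (0.38 log units; beyond the scatter) in the same direction. For the compounds shown here, the earlier swap at this place, with a 1.4-fold higher number from compound 1 to compound 2 (0.14 log units; within the scatter) as its step, stayed within the scatter, so exchanging one carbon-attached group for another showed no effect here, while the first group to put a nitrogen on the carbonyl carbon gives a step beyond the scatter. That entering group also brings one hydrogen-bond donor, but nothing in the data says why the number falls, and no measurement bears on the cause of this step.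

The compounds shown do not separate the role of the nitrogen from that of the propyl chain, as the change from 2-chloroethyl also removes the chlorine and alters the chain. Open, then, is how a shorter ethylamino group, a longer butylamino chain or a dimethylamino group, whose nitrogen carries no hydrogen, would compare with propylamino at this carbonyl carbon.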